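Allyl in place of carboxy: notes on compound 3

The compounds below may be only part of what the source reports. "The series", "measured", "known", "first", "only" and "open" are said of these compounds alone.

Measured so far:
compound 1 `COC(=O)c1ccc(OCc2nc(C)c(C)nc2C)c(OC)c1` — 16%
compound 2 `COc1cc(C(=O)O)ccc1OCc1nc(C)c(C)nc1C` — 19%

Among the compounds with values here, in a functional assay on ECV-304 cells (Homo sapiens), read by MTT assay, with stated times of 24 h and 12 h, tested at 100 uM (on this read-out lower numbers stand for a weaker effect and higher numbers for a stronger effect at the one concentration tested), compound 2 gives 19% and compound 1 gives 16%; the only measured step, a number 3 percentage points higher from compound 1 to compound 2 (within the scatter), is within the scatter, so the two cannot be told apart.

Compound 3 `C=CCc1ccc(OCc2nc(C)c(C)nc2C)c(OC)c1` differs from compound 2 by allyl in place of carboxy on an aromatic carbon. Within the data shown here, the single measured step touches the same carboxy group, but from the other side, and was small, so it bears only loosely on this change; both measured numbers are low. Compound 3 is therefore expected to show no step beyond the scatter, a number 2 percentage points lower from compound 2 to compound 3 (within the scatter), with an estimated 17% and a range of 5% to 35%.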

Compound 3, a percentage reported as activity, at one concentration (the size of the read-out at that concentration, not a potency): 36%
Compound 3: the middle estimate sits 19 percentage points below what was measured, and the stated range ends below it.
By their numbers in this assay, from the lowest: compounds 1 and 2 (each within the scatter of the next); then compound 3.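

In this assay, this carbon, para to a large group, proves sensitive to its substituent, which the two carbonyl-bearing groups alone did not reveal. Allyl in place of carboxy gives a number 17 percentage points higher from compound 2 to compound 3 (beyond the scatter), and allyl in place of methoxycarbonyl gives a number 20 percentage points higher from compound 1 to compound 3 (beyond the scatter), so allyl stands apart from both. Nothing available accounts for this rise.

Still open, as far as these compounds go, is whether the rise belongs to allyl specifically or would also appear with a propyl chain, a longer chain or an amine on this carbon. The role of the allyl double bond also remains unsettled.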